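Fluoro to methoxy on the benzyl ring of compound 2

This account rests on a few compounds, and the source may have more. Where it says the series, first, only, none or still open, it means among the compounds named here.

Measured compounds:
Compound 1: `CN1CCC[C@@H]1Cn1nc(Cc2ccc(O)cc2)c2ccccc2c1=O`, 398 nM
Compound 2: `CN1CCC[C@@H]1Cn1nc(Cc2cccc(F)c2)c2ccccc2c1=O`, 398 nM

In an assay for binding affinity to Alpha-1B adrenergic receptor (Homo sapiens) (on this read-out higher numbers stand for weaker inhibition and lower numbers for stronger inhibition), compound 2 `CN1CCC[C@@H]1Cn1nc(Cc2cccc(F)c2)c2ccccc2c1=O` gives 398 nM. Compound 1 gives 398 nM, so compound 2 stands level with compound 1. Within the data shown here, the single measured step, no change at the digits printed from compound 1 to compound 2 (within the scatter), shows that exchanging the group on the saturated chain carbon bound to an aromatic carbon left the read-out unmoved within the scatter.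

Compound 3 `COc1cccc(Cc2nn(C[C@H]3CCCN3C)c(=O)c3ccccc23)c1` differs from compound 2 by methoxy in place of fluoro on an aromatic carbon. Among the measured compounds shown here, only the step from compound 1 to compound 2 bears on this change, and it was flat, so a methoxy in place of fluoro on the same aromatic ring is expected to leave the read-out within the scatter as well. The step from compound 2 to compound 3 is therefore expected to be a 1.0-fold higher number from compound 2 to compound 3 (0.00 log units; within the scatter). For compound 3 the estimate in this assay is 400 nM, with a range from 150 nM to 1000 nM.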

Compound 3, inhibition constant: > 1990 nM
Compound 3: a limit, no number; the forecaster's own chance of this, stated with the estimate: 3%; at least 4.9-fold (0.69 log units) between middle value and limit.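

In this assay compound 3 gives > 1990 nM, which is a limit of the assay and not a number. Methoxy in place of fluoro gives an at least 5.0-fold higher number from compound 2 to compound 3 (0.69 log units; beyond the scatter), and 3-methoxyphenyl in place of 4-hydroxyphenyl gives an at least 5.0-fold higher number from compound 1 to compound 3 (0.69 log units; beyond the scatter), so the read-out at this ring is not indifferent to the group it carries, as the flat step no change at the digits printed from compound 1 to compound 2 (within the scatter) alone might have suggested. Both steps are lower bounds, and their full size cannot be read: the limit of > 1990 nM in this assay, at which 1 of the 3 values shown sits.

From the compounds shown here alone, it stays open whether this weakening belongs to methoxy alone or extends to other groups at this place, such as ethoxy, chloro or an amine. Going by these compounds, how far the read-out for compound 3 actually lies past its limit also remains unknown.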